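Shrinking the sulfonyl substituent of a shared sulfonamide core

The compounds below may be only part of what the source reports. "The series", "measured", "known", "first", "only" and "open" are said of these compounds alone.

Three sulfonamides built on one shared core have been tested in an assay on isolated protein for inhibition of malate dehydrogenase, mitochondrial (Sus scrofa), with stated times of 45 min and 30 min; on this read-out higher numbers stand for weaker inhibition and lower numbers for stronger inhibition. Compound 1 `COc1ccc(Cl)cc1S(=O)(=O)Nc1ccc2oc(-c3ccccc3)nc2c1` carries a 5-chloro-2-methoxyphenyl group on the sulfonyl sulfur; in this assay compound 1 gives only a limit, > 63000 nM. Compound 2 `O=S(=O)(Nc1ccc2oc(-c3ccccc3)nc2c1)c1ccc(O)cc1` carries a 4-hydroxyphenyl group there, and in this assay compound 2 likewise gives only a limit, > 63000 nM. Compound 3 `CCc1ccc(S(=O)(=O)Nc2ccc3oc(-c4ccccc4)nc3c2)cc1` carries a 4-ethylphenyl group, and in this assay compound 3 also gives only a limit, > 63000 nM. Because of the limit of > 63000 nM in this assay, at which 3 of the 3 values shown sit, none of the three can be ordered against the others: the steps a step that the two limits leave unreadable from compound 1 to compound 2, a step that the two limits leave unreadable from compound 1 to compound 3 and a step that the two limits leave unreadable from compound 2 to compound 3 all remain unreadable. Compound 4 `CS(=O)(=O)Nc1ccc2oc(-c3ccccc3)nc2c1` has not yet been measured; it differs from compound 3 by methyl in place of 4-ethylphenyl on a sulfonyl sulfur. Among the compounds with values here, no measured step bears on swapping an aromatic ring for a methyl, and every measured compound sits at the limit, so no step beyond the scatter can be read into this change in this assay. Compound 4 is therefore expected to give about 63000 nM, with a range from 20000 nM to 200000 nM, most probably again as a limit. The step of a number no higher from compound 3 to compound 4 (the limit leaves the size open) is estimated to be essentially none.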

Compound 4, half-maximal inhibitory concentration: > 63000 nM
Compound 4 was reported as a limit (the forecaster's own chance of this, stated with the estimate: 85%); the middle value lies on the limit itself.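

No step from compound 1, compound 2 or compound 3 to compound 4 can be read in this assay, because all four compounds share one limit: the limit of > 63000 nM in this assay, at which 4 of the 4 values shown sit.

The compounds shown leave open whether any group on the sulfonyl sulfur of this shared core gives measurable inhibition, and how these four groups would rank.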